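The source may hold more compounds than are shown below. What is called first, only, known or untested is meant among the compounds shown, and "the series" means these compounds.

Compound 2 `CCOC(=O)c1c(-c2ccc(OC)cc2)oc2ccc(OCCCCCN3C(=O)/C(=N\OC)c4cc(F)ccc43)cc12` and compound 1 `CCO/N=C1\C(=O)N(CCCCCOc2ccc3oc(-c4ccc(OC)cc4)c(C(=O)OCC)c3c2)c2ccc(F)cc21` differ in a single place: methyl in place of hydrogen on a saturated chain carbon bound to an oxygen on an unsaturated carbon. In an ADME assay on Vero cells (Chlorocebus sabaeus) for cytotoxicity, read by MTT assay, with a stated time of 72 h (a higher number here means that more compound is tolerated, a lower number that less compound is tolerated), compound 2 gives 32 ug/mL, and compound 1 gives 32 ug/mL, so that the step of no change at the digits printed from compound 2 to compound 1 (within the scatter) is flat. Compound 3 `CCOC(=O)c1c(-c2ccc(OC)cc2)oc2ccc(OCCCN3C(=O)/C(=N\OC)c4ccccc43)cc12` carries a shorter chain and a different core; how its core differs from that of compound 2 is not broken down here. In this assay compound 3 gives 128 ug/mL, the highest of the three numbers and beyond the scatter from both of the others. Compound 4 `CCO/N=C1\C(=O)N(CCCOc2ccc3oc(-c4ccc(OC)cc4)c(C(=O)OCC)c3c2)c2ccccc21` differs from compound 3 by methyl in place of hydrogen on a saturated chain carbon bound to an oxygen on an unsaturated carbon, the same change that was made from compound 2 to compound 1. Because the step of no change at the digits printed from compound 2 to compound 1 (within the scatter) stayed within the scatter, the step of no change at the digits printed from compound 3 to compound 4 (within the scatter) is expected to be equally flat. Compound 4 is therefore estimated at 128 ug/mL, within a range from 64 ug/mL to 256 ug/mL.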

Compound 4, half-maximal cytotoxic concentration: 16 ug/mL
The estimate for compound 4 lay 8.0-fold (0.90 log units) above the measured number; measured number below the stated range.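

In this assay, methyl in place of hydrogen on a saturated chain carbon bound to an oxygen on an unsaturated carbon gives an 8.0-fold lower number from compound 3 to compound 4 (0.90 log units; beyond the scatter). The change therefore does not carry over unchanged from one core to the other in this series, and the flat step cannot be assumed on another core: the same change on two cores in this assay, no change at the digits printed (within the scatter) from compound 2 to compound 1 and an 8.0-fold lower number (0.90 log units; beyond the scatter) from compound 3 to compound 4, 8.0-fold (0.90 log units) apart, beyond the scatter of two such steps

Among the compounds shown here, with only two pairs, which differ from each other in both chain and core, this does not show which of those differences goes with the gap, or how the step would run on a further core. The compounds shown leave open how a propoxy group in place of the ethoxy would behave on either core. They also leave open whether an amine or a carboxylic acid at the end of that chain would follow the same course.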